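Trimming the Unsaturated Amide Chain in Compound 3

This account rests on a few compounds, and the source may have more. Where it says the series, first, only, none or still open, it means among the compounds named here.

Compound 3 `CC(C)=CC(=O)Nc1c(C(O)(C(F)(F)F)C(F)(F)F)ccc2ccccc12` belongs to a small set of three amides built on the same core. In an assay on LtK cells with ATP-sensitive inward rectifier potassium channel 11 (Homo sapiens) as the target (a lower number here means that less compound is needed, a higher number that more compound is needed for the effect), compound 3 gives 46 nM, the second highest of the three numbers. The smallest amide, compound 1 `CC(=O)Nc1c(C(O)(C(F)(F)F)C(F)(F)F)ccc2ccccc12`, gives 18 nM in this assay, while compound 2 `CCC(CC)C(=O)Nc1c(C(O)(C(F)(F)F)C(F)(F)F)ccc2ccccc12` gives 4340 nM. The step from the methyl amide to the branched unsaturated one was modest, a 2.6-fold higher number from compound 1 to compound 3 (0.41 log units; beyond the scatter), whereas the two steps involving compound 2 were large: a 240-fold higher number from compound 1 to compound 2 (2.38 log units; beyond the scatter) and a 94-fold lower number from compound 2 to compound 3 (1.97 log units; beyond the scatter).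

Compound 4 `C/C=C/C(=O)Nc1c(C(O)(C(F)(F)F)C(F)(F)F)ccc2ccccc12` is obtained from compound 3 by the change (prop-1-en-1-yl in place of 2-methylprop-1-en-1-yl on a carbonyl carbon). This removes one carbon from the unsaturated group and brings compound 4 closer in size to compound 1, while keeping the double bond that compound 3 carries. Among the measured steps, the one from compound 1 to compound 3 bears most directly on this change, and it was only modest; the large losses seen with compound 2 came with a bulkier, saturated branched group that compound 4 does not carry. Compound 4 is therefore expected to sit between compound 1 and compound 3, with a step of a 1.5-fold lower number from compound 3 to compound 4 (0.19 log units; within the scatter) that may well fall within the scatter. The estimate for compound 4 in this assay is 30 nM, with a range of 10 nM to 90 nM.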

Compound 4, half-maximal effective concentration: 72 nM
For compound 4 the middle estimate is 2.4-fold (0.38 log units) below the measured one; the measured number falls inside the stated range.
By their numbers in this assay, from the lowest: compound 1; then compounds 3 and 4 (each within the scatter of the next); then compound 2.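

In this assay, taking one carbon out of the unsaturated group, so that prop-1-en-1-yl replaces 2-methylprop-1-en-1-yl on the carbonyl carbon, gives a 1.6-fold higher number from compound 3 to compound 4 (0.19 log units; within the scatter) and so leaves the two unsaturated amides indistinguishable at this position. The shorter group does not bring the number back to that of the methyl amide, as the modest step of a 4.0-fold higher number from compound 1 to compound 4 (0.60 log units; beyond the scatter) shows, yet it stays far from the branched saturated amide, with a 60-fold lower number from compound 2 to compound 4 (1.78 log units; beyond the scatter) as a large step. At this position, then, the number does not simply follow the carbon count of the group across these four compounds: the change tested here made no difference beyond the scatter, while the steps to methyl and to pentan-3-yl remain clear, and nothing measured here explains this pattern.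

A saturated propyl group on the same carbonyl carbon would show whether the double bond itself plays any part, a question that the pentan-3-yl amide cannot settle on its own. The compounds shown also leave open how a cyclopropyl ring, or an amine or a carboxylic acid at the end of a longer chain, would read at this position.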